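The source may report more compounds than this note shows. Statements on the series, on what has been measured and on what is new or still open speak of the compounds shown alone.

Of the compounds shown here, three of one series have been measured so far. Compound 1 `Clc1ccc(COc2ccccc2/C=C/C(/C=C/c2ccccn2)=N/Oc2ncnc3cc(Cl)ccc23)c(Cl)c1`, compound 2 `Clc1ccc(COc2ccc(/C=C/C(/C=C/c3ccccn3)=N/Oc3ncnc4ccccc34)cc2)cc1` and compound 3 `Cc1cccc(COc2ccc(/C=C/C(/C=C/c3ccccn3)=N/Oc3ncnc4cccc(C)c34)cc2)c1` share the same core and differ in the groups carried on the benzyl ether and on the quinazoline. In a functional assay on SMMC-7721 cells (Homo sapiens) for inhibition, read by MTT assay, with a stated time of 72 h, tested at 10 uM (on this read-out higher numbers stand for a stronger effect at the one concentration tested and lower numbers for a weaker effect), compound 1 gives 91.8%, compound 2 gives 94.4%, and compound 3 gives 97%. On these three numbers compound 2 sits in the middle, and its distance to compound 3 and to compound 1 is in each case within the usual scatter of this kind of measurement, so the three results cannot be told apart.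

Compound 4 `Clc1ccc(COc2ccc(/C=C/C(/C=C/c3ccccn3)=N/Oc3ncnc4ccccc34)cc2)c(Cl)c1` has not been measured in this assay. It differs from compound 2 in a single place: chloro in place of hydrogen on an aromatic carbon, so that the 4-chlorobenzyl ether of compound 2 becomes the 2,4-dichlorobenzyl ether of compound 4. Within the data shown here, no measured pair isolates that change. Since all three measured compounds, including compound 1 which already carries the 2,4-dichlorobenzyl group, lie within the scatter of one another, no step beyond the scatter is expected in this assay in either direction. The estimated change from compound 2 to compound 4 is a number 1.4 percentage points lower from compound 2 to compound 4 (within the scatter). For compound 4 the expected inhibition in this assay is 93%, with a range from 84% to 99%.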

Compound 4, a percentage reported as inhibition, at one concentration (the size of the read-out at that concentration, not a potency): 89.6%
Compound 4: middle estimate off by 3.4 percentage points, on the high side, and the stated range covers the measured number.
By their numbers in this assay, from the lowest: compounds 4, 1, 2 and 3 (each within the scatter of the next).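

Among these compounds, the pair of compound 2 and compound 4 is the first to isolate chloro in place of hydrogen on an aromatic carbon, ortho to a large group and meta to a chloro group. In this assay the change from 4-chlorobenzyl to 2,4-dichlorobenzyl gives a number 4.8 percentage points lower from compound 2 to compound 4 (within the scatter) at the one concentration tested, so this position takes the added chloro without a shift that can be told from repeat measurements. No measured information on this series offers an explanation for that outcome.

The compounds shown leave open whether another group on this same aromatic carbon, such as methoxy, an amine or a carboxylic acid, would move the read-out beyond the scatter. They also leave open whether this single change would look the same at any other concentration.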